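A change at the carbonyl of compound 1

The source may hold more compounds than are shown below. What is called first, only, known or untested is meant among the compounds shown, and "the series" means these compounds.

Compound 1 `COc1cc(-c2cc(/C=C/C(=O)c3ccc(N)cc3)[nH]n2)cc(OC)c1OC`, compound 2 `COc1ccc(-c2cc(/C=C/C(=O)c3ccc(N)cc3)[nH]n2)cc1OC` and compound 3 `COc1ccc(-c2cc(/C=C/C(=O)c3ccc(N)cc3)[nH]n2)cc1` share one core and differ only in the methoxy groups on one aromatic ring. In a functional assay on ACHN cells (Homo sapiens) for inhibition, read by sulforhodamine B assay, with a stated time of 48 h (a lower number here means a stronger inhibitor of growth, a higher number a weaker inhibitor of growth), compound 1 gives 1610 nM, compound 2 gives 1670 nM and compound 3 gives 2010 nM. Compound 1 has the lowest of the three numbers, yet both others sit within the scatter of it: the step of a 1.0-fold higher number from compound 1 to compound 2 (0.02 log units; within the scatter) and the step of a 1.2-fold higher number from compound 2 to compound 3 (0.08 log units; within the scatter) each came with hydrogen in place of methoxy on an aromatic carbon, and neither moved the number beyond the scatter.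

Compound 4 `COc1cc(-c2cc(/C=C/C(=O)c3ccc(F)c(F)c3)[nH]n2)cc(OC)c1OC` keeps the three methoxy groups of compound 1 and changes the other end of the molecule: 3,4-difluorophenyl in place of 4-aminophenyl on a carbonyl carbon. Neither measured step touches the carbonyl carbon; both concern methoxy groups and both were flat. The measured series thus gives no guide of its own to the size or direction of this change, and the flatness of the methoxy steps cannot simply be carried over to a change of a different kind. For compound 4 a step of a 1.6-fold higher number from compound 1 to compound 4 (0.19 log units; within the scatter) is expected, with wide uncertainty. Compound 4 is estimated at 2500 nM in this assay, within a range from 700 nM to 9000 nM.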

Compound 4, concentration for 50% growth inhibition: 3260 nM
Compound 4: the middle estimate sits 1.3-fold (0.12 log units) below what was measured; the measured number falls inside the stated range.
By their numbers in this assay, from the lowest: compounds 1, 2, 3 and 4 (each within the scatter of the next, the first and the last beyond it).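

Within the data shown here, putting 3,4-difluorophenyl in place of 4-aminophenyl on the carbonyl carbon gives the first step that lies beyond the scatter: in this assay, the change is a 2.0-fold higher number from compound 1 to compound 4 (0.31 log units; beyond the scatter). This end of the molecule therefore affects the number, whereas the two methoxy steps, a 1.0-fold higher number from compound 1 to compound 2 (0.02 log units; within the scatter) and a 1.2-fold higher number from compound 2 to compound 3 (0.08 log units; within the scatter), did not move it beyond the scatter, although the new step is modest and only just clears that limit. The change is also of a different kind, since the hydrogen-bond donor and acceptor counted in 4-aminophenyl are absent from 3,4-difluorophenyl, but no measurement shown here links the step to that difference or to any other feature of the two groups.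

A single swap removes the amine and adds the two fluorines together, so the compounds shown cannot separate the share of each; a plain phenyl, or a phenyl carrying one fluorine or a hydroxyl, on the same carbonyl carbon would bear on that. Also open, going by these compounds, is whether the same swap would give a similar step on the methoxy patterns of compound 2 and compound 3.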